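This account rests on a few compounds, and the source may have more. Where it says the series, first, only, none or still open, it means among the compounds named here.

Compound 1, `CCOC(=O)CCCOc1ccc(-c2nc3ncccn3c2NC2CCCCC2)cc1`: in a toxicity assay on A549 cells (Homo sapiens) for cytotoxicity, read by luminescence and CellTiter-Glo, with a stated time of 48 h (a higher number here means that more compound is tolerated, a lower number that less compound is tolerated), compound 1 reaches only the limit of the assay, > 100000 nM.
Compound 2, `c1cnc2nc(-c3ccc(OC4CCCC4)cc3)c(NC3CCCCC3)n2c1`: in this assay compound 2 gives 39000 nM.
Compound 3, `COc1ccc(-c2nc3ncccn3c2NC2CCCCC2)cc1`: in this assay compound 3 reaches only the limit of the assay, > 100000 nM.

Compound 3 therefore stands at the top of what was shown, sharing the limit with compound 1 (the limit of > 100000 nM in this assay, at which 2 of the 3 values shown sit). Among the compounds with values here, the only full number comes from compound 2, and the step of an at least 2.5-fold higher number from compound 2 to compound 3 (0.40 log units; beyond the scatter) shows compound 3 to be tolerated at least modestly better. The other steps are an at least 2.5-fold lower number from compound 1 to compound 2 (0.40 log units; beyond the scatter) and a step that the two limits leave unreadable from compound 1 to compound 3.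

Compound 4, `Cc1cc(Br)ccc1-c1nc2ncccn2c1NC1CCCCC1`, differs from compound 3 in one place: 4-bromo-2-methylphenyl in place of 4-methoxyphenyl on an aromatic carbon. All three measured steps vary the group carried on the oxygen on an aromatic ring; in compound 4 that oxygen is gone, so none of them maps onto this change directly. The nearest guide is that two of three values sit at the limit, and compound 4 is expected to behave similarly.

Compound 4 is expected to give about 80000 nM, within 30000 nM to 200000 nM. This estimate corresponds to an at least 1.2-fold lower number from compound 3 to compound 4 (0.09 log units; that floor lies within the scatter).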

Compound 4, half-maximal cytotoxic concentration: 45000 nM
The estimate for compound 4 lay 1.8-fold (0.25 log units) above the measured number, and the stated range covers the measured number.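

In this assay, within the data shown here, the earlier steps changed only the group on the oxygen, whereas this one shows that replacing the whole aromatic group on the five-membered ring also moves the number: 4-bromo-2-methylphenyl in place of 4-methoxyphenyl gives an at least 2.2-fold lower number from compound 3 to compound 4 (0.34 log units; beyond the scatter). The two groups have the same count of heavy atoms, but the entering group has no hydrogen-bond acceptor and carries bromine and a methyl group instead. Compound 3 sits at a limit of the assay, so only the floor of this step can be read, not its full size: the limit of > 100000 nM in this assay, at which 2 of the 4 values shown sit.

The compounds shown leave open whether the bromine, the methyl group or the loss of the methoxy group accounts for the step. On these data alone, a phenyl ring carrying only the bromine or only the methyl group would separate these, and an amine or a carboxylic acid on this ring remains unexplored here.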